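Oxan-4-yl in place of isopropyl on a carbonyl carbon

The source may hold more compounds than are shown below. What is called first, only, known or untested is meant among the compounds shown, and "the series" means these compounds.

In a physicochemical assay for solubility, read by mass spectrometry, in phosphate buffer, with a stated time of 24 h, at pH 7.4 (on this read-out higher numbers stand for higher solubility and lower numbers for lower solubility), compound 3 (`CC(C)C(=O)N1CCC(NC(=O)Nc2ccc(OC(F)(F)F)c(F)c2)CC1`) gives 5.3 ug/mL, the middle of three numbers. Compound 1 (`O=C(Nc1ccc(OC(F)(F)F)c(F)c1)NC1CCN(C(=O)C2CC2)CC1`) gives 19 ug/mL, and compound 2 (`CCOC(=O)N1CCC(NC(=O)Nc2ccc(OC(F)(F)F)c(F)c2)CC1`) gives 0.35 ug/mL. Compound 4 (`O=C(Nc1ccc(OC(F)(F)F)c(F)c1)NC1CCN(C(=O)C2CCOCC2)CC1`) carries oxan-4-yl in place of isopropyl on a carbonyl carbon. Going by the values given here, two measured steps bear on this place. One is modest, a 3.6-fold lower number from compound 1 to compound 3 (0.55 log units; beyond the scatter), and one is large, a 15-fold higher number from compound 2 to compound 3 (1.18 log units; beyond the scatter). Among the compounds with values here, no measured compound carries oxan-4-yl, so the direction remains uncertain, though a modest rise in this assay is expected. The expected change is a 2.6-fold higher number from compound 3 to compound 4 (0.42 log units; beyond the scatter). For compound 4 the estimate is 14 ug/mL, with an expected range from 3.5 ug/mL to 55 ug/mL.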

Compound 4, solubility: 77 ug/mL
Compound 4: the middle estimate sits 5.5-fold (0.74 log units) below what was measured; measured number outside the range, above it.
By their numbers in this assay, from the lowest: compound 2; then compound 3; then compound 1; then compound 4.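

In this assay, oxan-4-yl gives the highest number of the four groups on this carbonyl carbon, with a 15-fold higher number from compound 3 to compound 4 (1.16 log units; beyond the scatter) and a 4.1-fold higher number from compound 1 to compound 4 (0.61 log units; beyond the scatter) at this place. Neither isopropyl nor cyclopropyl therefore marks the top of the series, and the range at this position widens, with a 220-fold higher number from compound 2 to compound 4 (2.34 log units; beyond the scatter) at its full extent. On these data alone, what a cyclohexyl group would give here stays open, so the part played by the oxygen of oxan-4-yl cannot be told. The data shown give no explanation for these steps.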